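This account rests on a few compounds, and the source may have more. Where it says the series, first, only, none or still open, it means among the compounds named here.

Working notes on a short series of linear tetramines tested in a functional assay on L1210 cells (Mus musculus) for inhibition, with a stated time of 96 h; on this read-out lower numbers stand for stronger inhibition and higher numbers for weaker inhibition.

Compound 1 `CCNCCCNCCCNCC` is the shortest member. In this assay compound 1 gives 10000 nM. Compound 2 `CCNCCCCNCCCNCC` carries the change ((ethylamino)methyl in place of ethylamino on a saturated chain carbon, three bonds along the chain from an amine nitrogen), and in this assay compound 2 gives 700 nM; the step is a 14-fold lower number from compound 1 to compound 2 (1.15 log units; beyond the scatter). Compound 3 `CCNCCCCCNCCCCNCC` lengthens the chain once more, and in this assay compound 3 gives 200 nM; the step is a 3.5-fold lower number from compound 2 to compound 3 (0.54 log units; beyond the scatter). Each lengthening so far has lowered the number, the first by a large amount and the second by a modest one. The difference between the core of compound 3 and the core of compound 1 is not broken down here.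

Compound 4 `CCNCCCCCNCCCCCNCC` is not yet measured. Relative to compound 3 it carries (ethylamino)methyl in place of ethylamino on a saturated chain carbon, four bonds along the chain from an amine nitrogen. Within the data shown here, this is the same kind of change as the one from compound 1 to compound 2, but the place differs: there it sat three bonds along the chain from an amine nitrogen, here four bonds along the chain from an amine nitrogen. Given that the second lengthening, seen in the step of a 3.5-fold lower number from compound 2 to compound 3 (0.54 log units; beyond the scatter), brought less than the first, a further modest gain at most is expected, with the step from compound 3 to compound 4 estimated at a 2.0-fold lower number from compound 3 to compound 4 (0.30 log units; within the scatter). Compound 4 is thus expected to give about 100 nM in this assay, estimated to lie between 30 nM and 300 nM.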

Compound 4, half-maximal inhibitory concentration: 700 nM
Compound 4: middle estimate off by 7.0-fold (0.85 log units), on the low side; the whole stated range lies below it.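

In this assay the latest lengthening gives a 3.5-fold higher number from compound 3 to compound 4 (0.54 log units; beyond the scatter), so the fall in the number seen over the two earlier lengthenings does not continue, and compound 4 is the member that goes against that trend. The replacement of ethylamino by (ethylamino)methyl therefore does not carry from one core to another with a fixed size or even a fixed direction: the same change on two cores in this assay, a 14-fold lower number (1.15 log units; beyond the scatter) from compound 1 to compound 2 and a 3.5-fold higher number (0.54 log units; beyond the scatter) from compound 3 to compound 4, 50-fold (1.70 log units) apart, beyond the scatter of two such steps What this does not show is why the sign turns, since the two cases differ both in the core and in the place of the change, three bonds along the chain from an amine nitrogen in one and four bonds along the chain from an amine nitrogen in the other, and two pairs of compounds cannot separate these two factors or support a general rule for the series.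

The compounds shown leave open whether a longer chain on the core of compound 4 would raise the number further or leave it unchanged. They also leave open whether the same pattern would hold with methyl or propyl on the end amines in place of ethyl.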